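The source may report more compounds than this note shows. Statements on the series, on what has been measured and on what is new or still open speak of the compounds shown alone.

Compound 3 `COc1ccc(NC(=O)c2cccc(/C=C3\CC(=O)N(c4ccccc4)C3=O)c2)c(C)c1` stands at a limit in an ADME assay on HCT-116 cells (Homo sapiens) for cytotoxicity, read by MTT assay, with a stated time of 72 h; a higher number here means a weaker inhibitor, a lower number a stronger inhibitor: there compound 3 gives > 100000 nM, which is a limit of the assay and not a number. Compound 1 `O=C(NCC1CCCCC1)c1cccc(/C=C2\CC(=O)N(c3ccccc3)C2=O)c1` reaches the same limit; in this assay compound 1 gives > 100000 nM, a limit of the assay. Going by the values given here, compound 2 `CCOc1ccc(NC(=O)c2cccc(/C=C3\CC(=O)N(c4ccccc4)C3=O)c2)cc1` is the one compound with a number; in this assay compound 2 gives 84800 nM. The steps of an at least 1.1-fold lower number from compound 1 to compound 2 (0.07 log units; that floor lies within the scatter) and an at least 1.1-fold higher number from compound 2 to compound 3 (0.07 log units; that floor lies within the scatter) are floors within the scatter, and a step that the two limits leave unreadable from compound 1 to compound 3 cannot be read, so all three sit together at the limit of > 100000 nM in this assay, at which 2 of the 3 values shown sit. Compound 4 `Cc1ccc(NC(=O)c2cccc(/C=C3\CC(=O)N(c4ccccc4)C3=O)c2)cc1C` carries 3,4-dimethylphenyl in place of 4-methoxy-2-methylphenyl on an amide-type nitrogen. Among the compounds with values here, no measured step points away from the limit, so compound 4 is expected to give 100000 nM, between 50000 nM and 200000 nM. The estimated step of a number no higher from compound 3 to compound 4 (the limit leaves the size open) is expected to stay within the scatter.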

Compound 4, half-maximal inhibitory concentration: > 100000 nM
Compound 4 gave a limit, no number; the forecaster's own chance of this, stated with the estimate: 70%; the middle value sits exactly at the limit.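

Going by these compounds alone, with 3,4-dimethylphenyl on the amide-type nitrogen, an aryl group without an oxygen atom joins the earlier 4-ethoxyphenyl and 4-methoxy-2-methylphenyl groups, and this assay shows an at least 1.1-fold higher number from compound 2 to compound 4 (0.07 log units; that floor lies within the scatter) as the only readable step. The steps from compound 3 and from compound 1 to compound 4 cannot be read. Losing the oxygen atom therefore leaves the series where it was: the limit of > 100000 nM in this assay, at which 3 of the 4 values shown sit.

From the compounds shown here alone, whether an amine or a carboxylic acid on this aryl group would bring a compound clear of the limit remains open.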